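This account rests on a few compounds, and the source may have more. Where it says the series, first, only, none or still open, it means among the compounds named here.

Three compounds with a shared nitrothiophene-methyl group on a nitrogen were tested in a functional assay on HEK293 cells for agonist activity at nuclear receptor subfamily 1 group D member 1 (Homo sapiens), read by a luciferase reporter, with a stated time of 24 h; on this read-out higher numbers stand for an effect only at larger amounts of compound and lower numbers for an effect already at smaller amounts. Compound 1 `Cc1ccc(S(=O)(=O)N(CC(=O)OC(C)(C)C)Cc2ccc([N+](=O)[O-])s2)cc1` gives 3000 nM. Compound 2 `CC(C)(C)OC(=O)CN(Cc1ccc([N+](=O)[O-])s1)C(=O)c1cccc2ccccc12` gives 2600 nM, and compound 3 `O=C(c1cccc2ccccc12)N(Cc1ccc(Cl)cc1)Cc1ccc([N+](=O)[O-])s1` gives 2600 nM. All three numbers lie within the usual scatter of one another, so none can be called stronger or weaker than the rest.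

Compounds 2 and 3 differ in one place: 4-chlorophenyl in place of tert-butoxycarbonyl on a saturated chain carbon bound to an amide-type nitrogen. This change made no change at the digits printed from compound 2 to compound 3 (within the scatter).

Compound 1 and compound 2 have different cores; the difference between the two cores is not broken down here.

Compound 4 `Cc1ccc(S(=O)(=O)N(Cc2ccc(Cl)cc2)Cc2ccc([N+](=O)[O-])s2)cc1` carries the same kind of change on the core of compound 1: 4-chlorophenyl in place of tert-butoxycarbonyl on a saturated chain carbon bound to a sulfonamide nitrogen. The place differs in its surroundings, a saturated chain carbon bound to a sulfonamide nitrogen rather than to an amide-type nitrogen, so it is the same kind of change, not the same.

From compound 1 to compound 4 the step is expected to be no change at the digits printed from compound 1 to compound 4 (within the scatter), a small one, because no change at the digits printed from compound 2 to compound 3 (within the scatter) on the other core stayed within the scatter. Compound 4 is therefore estimated at 3000 nM, between 1400 nM and 6500 nM.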

Compound 4, half-maximal effective concentration: 2500 nM
The estimate for compound 4 lay 1.2-fold (0.08 log units) above the measured number; the range from low to high includes it.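

In this assay, putting 4-chlorophenyl in place of tert-butoxycarbonyl on a saturated chain carbon bound to a sulfonamide nitrogen gives a 1.2-fold lower number from compound 1 to compound 4 (0.08 log units; within the scatter) and matches the same kind of change on the other core: the same change on two cores in this assay, no change at the digits printed (within the scatter) from compound 2 to compound 3 and a 1.2-fold lower number (0.08 log units; within the scatter) from compound 1 to compound 4, 1.2-fold (0.08 log units) apart, within the scatter of two such steps

So on both cores this swap leaves the number within the usual scatter, and the two very different groups cannot be told apart in this read-out. This does not show that changes carry over in general: the comparison covers a single change on a single pair of cores, and neither step is large enough to test whether a real rise or fall would carry over.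

The compounds shown leave open whether a carboxylic acid in place of tert-butoxycarbonyl, or an amine on the same chain, would move the number beyond the scatter. They also leave open whether the nitrothiophene-methyl group, present in all four compounds, could be replaced without a change in the number.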